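The source may hold more compounds than are shown below. What is called first, only, known or untested is meant among the compounds shown, and "the series" means these compounds.

Values in an assay on HEK-293T cells for inhibition of diacylglycerol lipase-alpha (Homo sapiens), read by colorimetric assay; a lower number here means a stronger inhibitor, a higher number a weaker inhibitor:
compound 1 `O=C(CCCCCc1ccccc1)c1nc2ccccc2s1` gives > 10000 nM; this value is a limit of the assay, not a number.
compound 2 `CC(C)(C)C(=O)c1coc(C(=O)CCCCCCc2ccccc2)n1` gives 479 nM.
compound 3 `O=Cc1coc(C(=O)CCCCCCc2ccccc2)n1` gives 1510 nM.

Among the compounds with values here, compound 3 stands at the higher of the two numbers in this assay; its nearest neighbour is compound 2, and the only measured step is a 3.2-fold higher number from compound 2 to compound 3 (0.50 log units; beyond the scatter). Compound 1 sits at the limit (the limit of > 10000 nM in this assay, at which 1 of the 3 values shown sits).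

Compound 4 `CSc1coc(C(=O)CCCCCCc2ccccc2)n1` differs from compound 3 by methylsulfanyl in place of formyl on an aromatic carbon. The step from compound 2 to compound 3 altered the group on a carbonyl carbon at the same position of the shared core and shifted the number modestly upward. Within the data shown here, the present change removes the carbonyl at that position altogether, so no measured step matches it in kind; the step from compound 2 to compound 3 is the only guide, and it points to a weaker inhibitor rather than a stronger one. A step of a 3.3-fold higher number from compound 3 to compound 4 (0.52 log units; beyond the scatter) in this assay is therefore expected, with a real chance that only a limit is reported. Compound 4 is estimated at 5000 nM, within 1500 nM to 20000 nM.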

Compound 4, half-maximal inhibitory concentration: > 10000 nM
Compound 4 was reported as a limit; the forecaster's own chance of this, stated with the estimate: 40%; middle value at least 2.0-fold (0.30 log units) away from the limit.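

In this assay compound 4 gives > 10000 nM, a limit of the assay and not a number, and it shares this limit with compound 1: the limit of > 10000 nM in this assay, at which 2 of the 4 values shown sit.

Methylsulfanyl on this aromatic carbon gives an at least 6.6-fold higher number from compound 3 to compound 4 (0.82 log units; beyond the scatter), and set against (tert-butyl)carbonyl it gives an at least 20-fold higher number from compound 2 to compound 4 (1.31 log units; beyond the scatter). Compound 2 and compound 3 both carry a carbonyl on this carbon and both give numbers, while compound 4 has no carbonyl there and gives only a limit, a pattern that rests on these three compounds alone.

Going by these compounds, both new steps are bounded on one side only, so their true size stays open. On these data alone, whether a methyl ketone, an amide or a carboxylic acid on this carbon would keep a measurable number, and how an amine would compare with methylsulfanyl, also stays open.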